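A few compounds are considered here, and "the series" means these few. Any claim that something is new, unique, unknown or untested is made for them only; others in the source may bear on it.

Measured in an assay on CHO cells for displacement of a labelled ligand from adenosine receptor A1 (Homo sapiens), read by scintillation counting, with a stated time of 90 min; on this read-out higher numbers stand for weaker inhibition and lower numbers for stronger inhibition:
Compound 1 `Cc1ccc(-c2nc3c(N)nc(NCc4cccs4)nc3s2)o1`: 71 nM
Compound 2 `Nc1nc(NCc2ccco2)nc2sc(-c3ccco3)nc12`: 38 nM

Among the measured compounds shown here, only two compounds have been measured, and the numbers for compound 1 and compound 2 lie within the usual scatter of each other, so neither can be set above the other. Compound 3 `Nc1nc(NCc2ccsc2)nc2sc(-c3ccco3)nc12` differs from compound 2 in one place: thiophen-3-yl in place of furan-2-yl on a saturated chain carbon bound to a nitrogen on an aromatic ring. Both groups are five-membered aromatic rings of the same size, so no step beyond the scatter is expected in this assay in either direction. The expected step from compound 2 to compound 3 is a 1.3-fold higher number from compound 2 to compound 3 (0.12 log units; within the scatter). Compound 3 is estimated to give 50 nM, with a range from 18 nM to 150 nM.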

Compound 3, inhibition constant: 8.12 nM
Compound 3: the middle estimate sits 6.2-fold (0.79 log units) above what was measured; measured number outside the range, below it.
By their numbers in this assay, from the lowest: compound 3; then compounds 2 and 1 (each within the scatter of the next).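

In this assay, placing thiophen-3-yl in place of furan-2-yl on a saturated chain carbon bound to a nitrogen on an aromatic ring gives a 4.7-fold lower number from compound 2 to compound 3 (0.67 log units; beyond the scatter) and so moves the number beyond the scatter. This position therefore responds to the choice between two five-membered aromatic rings of equal size, which compound 1 and compound 2 could not show, since they differ in more than one place. No evidence here accounts for this step.

The change alters both the ring atom and the point of attachment, so furan-3-yl on the same core would be needed to separate the two. As far as these compounds go, whether a larger ring such as phenyl is accepted at this position also stays open.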